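A few compounds are considered here, and "the series" means these few. Any claim that something is new, unique, unknown or untested is made for them only; others in the source may bear on it.

Measured so far in a functional assay on CHO cells for agonist activity at Free fatty acid receptor 1 (Homo sapiens); on this read-out lower numbers stand for an effect already at smaller amounts and higher numbers for an effect only at larger amounts of compound:
compound 1 `CNC(=O)CCc1ccc(NCc2cccc(Oc3ccccc3)c2)cc1`, 49 nM
compound 2 `CC(C)NC(=O)CCc1ccc(NCc2cccc(Oc3ccccc3)c2)cc1`, 39.8 nM

Compound 2 and compound 1 share the same core and differ only on the amide-type nitrogen. Going by the values given here, the one measured step, a 1.2-fold lower number from compound 1 to compound 2 (0.09 log units; within the scatter), is within the scatter, so the two numbers cannot be told apart; compound 2 therefore stands level with compound 1, and the series so far gives no step beyond the scatter in this assay.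

Compound 3 `CC(C)NC(=O)[C@H]1C[C@@H]1c1ccc(NCc2cccc(Oc3ccccc3)c2)cc1` is not yet measured. Its change from compound 2 is 2-(isopropylcarbamoyl)cyclopropyl in place of 2-(isopropylcarbamoyl)ethyl on an aromatic carbon. The isopropylcarbamoyl amide is kept; what changes is the link between that amide and the aromatic carbon. Among the compounds with values here, no measured step touches this link: the step from compound 1 to compound 2 concerns the amide nitrogen substituent only and does not inform on the chain. There is thus no shown step from which a direction can be read, and the expectation rests on compound 2 alone. The step is expected to be a 1.3-fold higher number from compound 2 to compound 3 (0.10 log units; within the scatter), with a range wide enough to cover either direction. For compound 3 the estimate in this assay is 50 nM, between 12 nM and 250 nM.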

Compound 3, half-maximal effective concentration: 12.6 nM
The estimate for compound 3 lay 4.0-fold (0.60 log units) above the measured number; the measured number falls inside the stated range.
By their numbers in this assay, from the lowest: compound 3; then compounds 2 and 1 (each within the scatter of the next).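

In this assay, going by these compounds alone, the link between the isopropylcarbamoyl amide and the aromatic carbon para to a large group proves to be a place where the number moves: 2-(isopropylcarbamoyl)cyclopropyl in place of 2-(isopropylcarbamoyl)ethyl gives a 3.2-fold lower number from compound 2 to compound 3 (0.50 log units; beyond the scatter) and is the first step beyond the scatter, whereas the change on the amide nitrogen alone stayed within it. The comparison with the methylcarbamoyl chain reads the same way, at a 3.9-fold lower number from compound 1 to compound 3 (0.59 log units; beyond the scatter) and so compound 3 holds the lowest number of the three, with modest steps to both others. Nothing at hand explains the difference between the cyclopropyl link and the open chain.

From the compounds shown here alone, only one stereochemical form of the cyclopropyl link appears here, so its mirror image and the other relative arrangement of the ring substituents remain open, as does whether the methyl amide on the same link would follow compound 3. Also open, going by these compounds, is how a carboxylic acid in place of the amide, or a longer chain between the aromatic carbon and the carbonyl, would read in this assay.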